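The source may report more compounds than this note shows. Statements on the series, on what has been measured and on what is new or still open speak of the compounds shown alone.

Measured in a functional assay on NCI-H460 cells (Homo sapiens) for cytotoxicity, read by MTT assay, with a stated time of 96 h; on this read-out higher numbers stand for weaker inhibition and lower numbers for stronger inhibition:
Compound 1 `COc1ncc(-c2cc(OCC3CCOCC3)c3nc(N)nc(C)c3c2)cc1NS(=O)(=O)c1ccc(F)cc1F`: 21 nM
Compound 2 `COc1ncc(-c2cc(OC3CCOCC3)c3nc(N)nc(C)c3c2)cc1NS(C)(=O)=O`: 860 nM

Compound 2 has the higher of the two numbers, and its gap to compound 1 lies beyond the scatter. Compound 3 `COc1ncc(-c2cc(OC3CCOCC3)c3nc(N)nc(C)c3c2)cc1NS(=O)(=O)c1ccc(F)cc1` has 4-fluorophenyl in place of methyl on a sulfonyl sulfur. Compound 1 also carries an aromatic ring on its sulfonyl sulfur and gives 21 nM, although it differs from compound 2 in more than one place. A clear fall in the number is therefore expected in this assay, with an estimated 22-fold lower number from compound 2 to compound 3 (1.33 log units; beyond the scatter). The expected value for compound 3 is 40 nM, with an estimated range of 12 nM to 140 nM.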

Compound 3, half-maximal inhibitory concentration: 96 nM
Beside the measured number, compound 3's estimate is 2.4-fold (0.38 log units) below it, within the range that was stated.
By their numbers in this assay, from the lowest: compound 1; then compound 3; then compound 2.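

In this assay, the group on the sulfonyl sulfur matters on its own: with 4-fluorophenyl in place of methyl, the change gives a 9.0-fold lower number from compound 2 to compound 3 (0.95 log units; beyond the scatter). For the compounds shown here, compound 1 had hinted at this, but it differs from compound 2 in more than one place, so this is the first reading of the change alone. No evidence at hand accounts for the size of the step.

As far as these compounds go, whether an unsubstituted phenyl or a longer alkyl chain on the sulfur would do as well remains open. So does how the gap to compound 1 divides among its differences from compound 3.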